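A few compounds are considered here, and "the series" means these few. Any claim that something is new, unique, unknown or untested is made for them only; others in the source may bear on it.

Among the measured compounds shown here, in a functional assay on HeLa cells (Homo sapiens) for cytotoxicity, read by resazurin assay, with a stated time of 72 h (a higher number here means a weaker inhibitor, a lower number a stronger inhibitor), two compounds have measured values so far: compound 1 (`COc1cc(/C=C/C(=O)OCCCCOc2no[n+]([O-])c2S(=O)(=O)c2ccccc2)ccc1O`) gives 460 nM and compound 2 (`O=C(/C=C/c1ccc(O)c(O)c1)OCc1c(-c2ccccc2)no[n+]1[O-]`) gives 1230 nM. Compound 2 therefore holds the higher number of the two, and its gap to compound 1 lies beyond the scatter. Compound 3 (`COc1cc(/C=C/C(=O)OCc2c(-c3ccccc3)no[n+]2[O-])ccc1O`) departs from compound 2 in one place: methyl in place of hydrogen on an oxygen on an aromatic ring. This puts methyl in place of hydrogen on an oxygen on an aromatic ring, turning 3,4-dihydroxyphenyl into 4-hydroxy-3-methoxyphenyl. Compound 1 also carries 4-hydroxy-3-methoxyphenyl but differs from compound 3 elsewhere, so the pair does not isolate this change. For the measured compounds named here, no measured pair shows the step alone, and the data give only a weak guide to its size. Taking compound 2 at 1230 nM as the anchor, a modest move towards a higher number is expected in this assay, and it may not exceed the scatter. The expected change is a 1.5-fold higher number from compound 2 to compound 3 (0.17 log units; within the scatter). For compound 3 the estimate is 1800 nM, with an expected range from 700 nM to 4800 nM.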

Compound 3, half-maximal inhibitory concentration: 7820 nM
Compound 3: middle estimate off by 4.3-fold (0.64 log units), on the low side, outside the stated range (above it).
By their numbers in this assay, from the lowest: compound 1; then compound 2; then compound 3.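

In this assay, among the compounds shown here, the change from 3,4-dihydroxyphenyl to 4-hydroxy-3-methoxyphenyl gives a 6.4-fold higher number from compound 2 to compound 3 (0.80 log units; beyond the scatter), the first step that isolates a single change. The oxygen on the aromatic ring is therefore sensitive to substitution on this core: one methyl in place of hydrogen, with the rest of the structure held constant, moves the result towards a weaker inhibitor by more than the scatter, and the free hydroxy form is the stronger of this pair. Nothing available speaks to the cause of this shift.

Still open, as far as these compounds go, is whether the step reflects the loss of the hydrogen or the arrival of the methyl, a question that an ethoxy or acetoxy group on the same oxygen would help to separate. Also open, from the compounds shown here alone, is whether a step of this size holds on the core of compound 1, since one pair on one core cannot show whether the change carries over to a different framework.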